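Swapping the Amide Aryl Group: Ethyl for Methoxy

A few compounds are considered here, and "the series" means these few. Any claim that something is new, unique, unknown or untested is made for them only; others in the source may bear on it.

Of the compounds shown here, three sharing one core have been measured. Compound 1 `CCc1cccc(NC(=O)c2cccc(/C=C3\CC(=O)N(c4ccccc4)C3=O)c2)c1` carries a 3-ethylphenyl group on its amide nitrogen. In an ADME assay on SW480 cells (Homo sapiens) for cytotoxicity, read by MTT assay, with a stated time of 72 h (a lower number here means a stronger inhibitor, a higher number a weaker inhibitor), compound 1 gives 88600 nM. Compound 2 `Cc1ccc(N2C(=O)C/C(=C\c3cccc(C(=O)Nc4ccc(Cl)cc4)c3)C2=O)cc1` carries a 4-chlorophenyl group there instead. In this assay compound 2 gives > 100000 nM, which is a limit of the assay and not a number. Compound 3 `COc1ccc(NC(=O)c2cccc(/C=C3\CC(=O)N(c4ccc(C)cc4)C3=O)c2)cc1` carries a 4-methoxyphenyl group on that nitrogen. In this assay, within the data shown here, compound 3 gives 93000 nM, a number that sits within the usual scatter of the one for compound 1, so the two cannot be told apart.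

Among the measured compounds shown here, one measured step touches the amide-side aryl group: an at least 1.0-fold lower number from compound 2 to compound 3 (0.03 log units; that floor lies within the scatter), with compound 2 resting at the limit of > 100000 nM in this assay, at which 1 of the 3 values shown sits. Compound 4 `CCc1cccc(NC(=O)c2cccc(/C=C3\CC(=O)N(c4ccc(C)cc4)C3=O)c2)c1` differs from compound 3 by 3-ethylphenyl in place of 4-methoxyphenyl on an amide-type nitrogen. Compound 1 already carries that 3-ethylphenyl group, though it differs from compound 3 elsewhere as well, and its value lies within the scatter of compound 3's. No step beyond the scatter is therefore expected for a 1.0-fold lower number from compound 3 to compound 4 (0.01 log units; within the scatter). Compound 4 is estimated at 90000 nM, with a range from 40000 nM to 200000 nM.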

Compound 4, half-maximal inhibitory concentration: 65300 nM
Compound 4: the middle estimate sits 1.4-fold (0.14 log units) above what was measured, within the range that was stated.
By their numbers in this assay, from the lowest: compounds 4, 1 and 3 (each within the scatter of the next). At a limit, above all of these: compound 2.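

In this assay, 3-ethylphenyl in place of 4-methoxyphenyl on the amide-type nitrogen gives a 1.4-fold lower number from compound 3 to compound 4 (0.15 log units; within the scatter), so this exchange, now seen with the rest of the molecule unchanged, does not move the number beyond the scatter, and neither does methyl in place of hydrogen on an aromatic carbon, which gives a 1.4-fold lower number from compound 1 to compound 4 (0.13 log units; within the scatter). The exchange of 4-chlorophenyl for 3-ethylphenyl gives an at least 1.5-fold lower number from compound 2 to compound 4 (0.18 log units; that floor lies within the scatter), and this is only a floor for that step. Compound 2 stands at a limit of the assay and not at a number: the limit of > 100000 nM in this assay, at which 1 of the 4 values shown sits.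

The compounds shown leave open whether a step beyond the scatter can be reached at this position. A phenyl ring carrying an amine or a carboxylic acid, or a longer chain in place of the ethyl, could test that.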